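This account rests on a few compounds, and the source may have more. Where it says the series, first, only, none or still open, it means among the compounds named here.

Measured so far in this set:

compound 1, `C/N=C(\S)NCCCCCn1nc(-c2ccccc2)ccc1=O`: 35.3 mg/kg
compound 2, `N#CNC(=N)NCCCCn1nc(-c2ccccc2)ccc1=O`: 77.2 mg/kg

Both numbers come from a functional assay on the whole organism (stomach) with Rattus norvegicus as the target; on this read-out lower numbers stand for an effect already at smaller amounts and higher numbers for an effect only at larger amounts of compound. Among the two values shown, compound 2 stands highest; its only neighbour is compound 1, and the step between them is a 2.2-fold higher number from compound 1 to compound 2 (0.34 log units; beyond the scatter), a modest rise that lies beyond the scatter.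

Compound 3, `CC(C)C/N=C(\S)NCCCCn1nc(-c2ccccc2)ccc1=O`, has not been measured yet. Against compound 2 the change is a group of 7 heavy atoms (5 carbon, 1 nitrogen, 1 sulfur; no ring) in place of a group of 5 heavy atoms (2 carbon, 3 nitrogen; no ring), on an amine nitrogen. Within the data shown here, only one measured step bears on this change: a 2.2-fold higher number from compound 1 to compound 2 (0.34 log units; beyond the scatter), in which a sulfur-containing group gave way to a nitrogen-rich, sulfur-free group and the number went up. The change to compound 3 runs the other way, bringing a sulfur-containing group back, with more carbon than before. The reverse of a modest, beyond-scatter rise is therefore the natural expectation: a modest fall in this assay, roughly undoing the step from compound 1 to compound 2, with the extra carbon an unknown of its own.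

Compound 3 is therefore expected to give about 35 mg/kg in this assay, within a range of 15 mg/kg to 80 mg/kg. This estimate amounts to an expected 2.2-fold lower number from compound 2 to compound 3 (0.34 log units; beyond the scatter).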

Compound 3, dose for half-maximal effect: > 100 mg/kg
Compound 3 was reported as a limit; the forecaster's own chance of this, stated with the estimate: 5%; middle value at least 2.8-fold (0.45 log units) from the limit.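

In this assay compound 3 gives > 100 mg/kg, which is a limit of the assay and not a number. Putting a sulfur-containing group back did not bring back the lower number of compound 1: the comparison reads an at least 2.8-fold higher number from compound 1 to compound 3 (0.45 log units; beyond the scatter), so within these compounds sulfur in the group is not enough for an effect at smaller amounts, and compound 3 is the one that goes against any link between sulfur and a lower number. The comparison with the sulfur-free group reads an at least 1.2-fold higher number from compound 2 to compound 3 (0.11 log units; that floor lies within the scatter), and that floor on its own does not separate the two compounds, so the limit leaves their true order unsettled.

How far the true value of compound 3 lies past the limit stays open, as does the question of which part of the difference from compound 1, the larger carbon group or the rest of the change along the chain, accounts for the rise. An ethyl group on the same nitrogen, or a simple amine in place of the whole sulfur-containing group, would help to tell these apart.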